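Diethylamino to piperidin-1-yl: notes on compound 3

The source may hold more compounds than are shown below. What is called first, only, known or untested is meant among the compounds shown, and "the series" means these compounds.

Among the measured compounds shown here, in a functional assay on HepG2 cells (Homo sapiens) for cytotoxicity, read by MTT assay, with a stated time of 48 h (on this read-out lower numbers stand for stronger inhibition and higher numbers for weaker inhibition), compound 1 (`Cc1ccc2oc(-c3ccc(N)cc3)cc(=O)c2c1`) reads 21300 nM and gives the only number so far. Compound 2 (`CCN(CC)Cc1ccc2oc(-c3ccc(N)cc3)cc(=O)c2c1`) stands at "not determined" (no result reported) in this assay and has no number of its own. Compound 3 (`Nc1ccc(-c2cc(=O)c3cc(CN4CCCCC4)ccc3o2)cc1`) carries piperidin-1-yl in place of diethylamino on a saturated chain carbon bound to an aromatic carbon. For the measured compounds named here, no measured step exists for this change, and none beyond the scatter is expected in this assay in either direction. The expectation for compound 3 rests on compound 1 at 21300 nM alone. Compound 3 is expected at 15000 nM with an estimated range from 5000 nM to 45000 nM in this test.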

Compound 3, half-maximal inhibitory concentration: 2640 nM
Compound 3: middle estimate off by 5.7-fold (0.75 log units), on the high side; measured number outside the range, below it.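

On a saturated chain carbon bound to an aromatic carbon, piperidin-1-yl in place of hydrogen gives an 8.1-fold lower number from compound 1 to compound 3 (0.91 log units; beyond the scatter) in this assay and this place on the core of compound 1 now has a measured step beyond the scatter. Compound 2 has no number, and the change from diethylamino to piperidin-1-yl cannot be read. No data at hand explain the step.

Still open, going by these compounds, is how a morpholine ring or a dimethylamino group would read in this place. With a single amine measured here, no trend across amines can be stated.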